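A few compounds are considered here, and "the series" means these few. Any claim that something is new, unique, unknown or untested is made for them only; others in the source may bear on it.

Compounds measured so far in a functional assay on HEK293 cells with D(4) dopamine receptor (Homo sapiens) as the target, read by FLIPR; on this read-out higher numbers stand for an effect only at larger amounts of compound and lower numbers for an effect already at smaller amounts:
compound 1 `Cc1ccccc1/C(CCN1CCN(c2ccccn2)CC1)=N/O` — 4.2 nM
compound 2 `N#Cc1cccc(/C(CCN2CCN(c3ccccn3)CC2)=N/O)c1` — 13.1 nM
compound 3 `O/N=C(\CCN1CCN(c2ccccn2)CC1)c1ccc(F)cc1` — 31 nM

All three share the same core and differ only in the aromatic ring attached to the carbon that carries the double bond to nitrogen. Compound 3 gives the highest number of the three in this assay: next to it stands compound 2, with a 2.4-fold higher number from compound 2 to compound 3 (0.37 log units; beyond the scatter), and furthest away stands compound 1, with a 7.4-fold higher number from compound 1 to compound 3 (0.87 log units; beyond the scatter). The step between the two other compounds, a 3.1-fold higher number from compound 1 to compound 2 (0.49 log units; beyond the scatter), is of a similar modest size.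

Compound 4 `O/N=C(\CCN1CCN(c2ccccn2)CC1)c1cc(F)cc(F)c1` is the next compound. It is built from compound 3 by a change at the same position: 3,5-difluorophenyl in place of 4-fluorophenyl on a carbon with a double bond to nitrogen. Within the data shown here, none of the measured steps swaps one fluorinated ring for another with a different fluorine count, so there is no step that bears directly on this change. What the measured steps do show is that varying the substituent pattern on this ring moved the number in this assay by modest amounts in every case, never by a large one.

Compound 4 is therefore expected to land close to compound 3, with a step of about a 1.0-fold lower number from compound 3 to compound 4 (0.01 log units; within the scatter) in this assay. The estimate for compound 4 is 30 nM, within a range from 9 nM to 100 nM.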

Compound 4, half-maximal effective concentration: 19.4 nM
Compound 4: the middle estimate sits 1.5-fold (0.19 log units) above what was measured, and the stated range covers the measured number.
By their numbers in this assay, from the lowest: compound 1; then compounds 2, 4 and 3 (each within the scatter of the next, the first and the last beyond it).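

Swapping 4-fluorophenyl for 3,5-difluorophenyl on the carbon with a double bond to nitrogen gives a 1.6-fold lower number from compound 3 to compound 4 (0.20 log units; within the scatter) in this assay, the first step at this position that does not clearly separate two compounds. The swap from 3-cyanophenyl to 3,5-difluorophenyl is also small, at a 1.5-fold higher number from compound 2 to compound 4 (0.17 log units; within the scatter), so compound 4 lies within the scatter of both compound 2 and compound 3, even though those two are separated by more than the scatter. Only the 2-methylphenyl ring stands apart, with a 4.6-fold higher number from compound 1 to compound 4 (0.66 log units; beyond the scatter), and compound 1 now has the lowest number of the four, clear of each of the others.

The compounds shown do not settle whether that low number depends on the methyl group itself or on where it sits on the ring, a question that a 2-fluorophenyl or 2-methoxyphenyl ring at this position could help to answer. They also offer no measurement that explains the differences among these rings.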